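This account rests on a few compounds, and the source may have more. Where it says the series, first, only, none or still open, it means among the compounds named here.

Measured so far in a functional assay on MCF7 cells (Homo sapiens) for inhibition, read by sulforhodamine B assay, with a stated time of 72 h; a higher number here means a weaker inhibitor, a lower number a stronger inhibitor:
compound 1 `O=C(/C=C/c1cn(-c2ccccc2)nc1-c1cccnc1)c1ccsc1` gives 500 nM
compound 2 `COc1ccc(C(=O)/C=C/c2cn(-c3ccccc3)nc2-c2cccnc2)c(OC)c1` gives 2300 nM
compound 3 `O=C(/C=C/c1cn(-c2ccccc2)nc1-c1ccncc1)c1ccsc1` gives 1500 nM

Compound 3 holds the second highest number of the three. Its nearest neighbour is compound 2, whose number sits within the scatter of that of compound 3, so no order between these two can be drawn. Compound 1 stands apart from both: the step of a 3.0-fold higher number from compound 1 to compound 3 (0.48 log units; beyond the scatter) was modest but clear, as was a 4.6-fold higher number from compound 1 to compound 2 (0.66 log units; beyond the scatter).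

The next compound, compound 4 `COc1ccc(OC)c(C(=O)/C=C/c2cn(-c3ccccc3)nc2-c2ccncc2)c1`, differs from compound 3 in one place: 2,5-dimethoxyphenyl in place of thiophen-3-yl on a carbonyl carbon. The measured step that bears on this exchange is a 4.6-fold higher number from compound 1 to compound 2 (0.66 log units; beyond the scatter), where the same thiophen-3-yl left the carbonyl carbon and a dimethoxyphenyl with a different substitution pattern entered, while the rest of the molecule stayed fixed. That step was modest and pointed toward a higher number in this assay. The dimethoxyphenyl entering compound 4 is not the same as that of compound 2, and the pyridyl attached to the core is different, so the transfer is approximate. Still, a step of similar size and direction is the working expectation, and the estimated step from compound 3 to compound 4 is a 4.0-fold higher number from compound 3 to compound 4 (0.60 log units; beyond the scatter). Compound 4 is therefore expected to give about 6000 nM, within 2500 nM to 15000 nM.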

Compound 4, half-maximal inhibitory concentration: 1400 nM
Compound 4: middle estimate off by 4.3-fold (0.63 log units), on the high side; measured number outside the range, below it.
By their numbers in this assay, from the lowest: compound 1; then compounds 4, 3 and 2 (each within the scatter of the next).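

Working from the pyridin-4-yl series, 2,5-dimethoxyphenyl in place of thiophen-3-yl on a carbonyl carbon gives a 1.1-fold lower number from compound 3 to compound 4 (0.03 log units; within the scatter) in this assay, so at this position the two groups cannot be told apart in this pair, although the entering group is an uncharged six-membered carbon ring bearing two methoxy groups rather than a five-membered ring with sulfur. The earlier exchange, a 4.6-fold higher number from compound 1 to compound 2 (0.66 log units; beyond the scatter), lay beyond the scatter, so leaving thiophen-3-yl for a dimethoxyphenyl on this carbon does not carry one fixed step through the two pairs shown. No measurement at hand accounts for the difference between the two steps.

The two steps differ both in the dimethoxyphenyl pattern and in the pyridyl on the core, and the compounds shown do not separate these two variables, leaving open which of them goes with the difference. Also open, as far as these compounds go, is how an amine or a carboxylic acid on the aryl group at the carbonyl carbon would read in this assay, as would a longer alkyl chain there in place of the aryl group.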